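This account rests on a few compounds, and the source may have more. Where it says the series, first, only, none or still open, it means among the compounds named here.

Compound 1, `C[C@H](NC(=O)[C@@]1(Cc2ccccc2)CCN1C(=O)OCc1ccccc1)C(=O)NC(C)(C)C`, gives > 100000 nM in an ADME assay on HELF cells (Homo sapiens) for cytotoxicity, with a stated time of 3 days; a lower number here means that less compound is tolerated, a higher number that more compound is tolerated; this is a limit of the assay, not a number. Compound 2, `C[C@H](NC(=O)[C@]1(Cc2ccccc2)CCN1C(=O)Oc1cccc2ccccc12)C(N)=O`, gives > 100000 nM in this assay, again a limit. Compound 3, `C[C@H](NC(=O)[C@]1(Cc2ccccc2)CCN1C(=O)OCc1ccccc1)C(=O)NC(C)(C)C`, gives > 100000 nM in this assay, also a limit.

Compound 1 therefore stands at the limit of this assay, and so do both other values shown (the limit of > 100000 nM in this assay, at which 3 of the 3 values shown sit). For the measured compounds named here, the one measured step, a step that the two limits leave unreadable from compound 1 to compound 3, is unreadable, since both ends are limits; these two compounds differ only in drawn configuration (the fact that compounds 1 and 3 differ only in the configuration as drawn). Compound 4, `CC(C)CNC(=O)[C@H](C)NC(=O)[C@@]1(Cc2ccccc2)CCN1C(=O)OCc1ccccc1`, carries a different change: isobutyl in place of tert-butyl on an amide-type nitrogen. Going by the values given here, no measured step covers this change, and no step anywhere here has a readable size. The expectation for compound 4 is thus no step beyond the scatter, a step that the limit leaves unreadable from compound 1 to compound 4, with compound 4 estimated at 150000 nM, between 70000 nM and 350000 nM.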

Compound 4, minimum cytotoxic concentration: > 100000 nM
Compound 4 ended at the assay's limit (the forecaster's own chance of this, stated with the estimate: 85%); the middle value does not contradict the limit.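

Compound 1 and compound 4 both give limits, not numbers, in this assay, so no step between them can be read: the limit of > 100000 nM in this assay, at which 4 of the 4 values shown sit.

The compounds shown leave open what concentration first harms these cells, and whether isobutyl in place of tert-butyl changes it at all.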